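A few compounds are considered here, and "the series" means these few. Any claim that something is new, unique, unknown or untested is made for them only; others in the source may bear on it.

Working notes on the series, measured in a functional assay on CCRF-SB cells (Homo sapiens); on this read-out lower numbers stand for stronger inhibition and higher numbers for weaker inhibition:

- compound 1 `NC(=O)c1nn([C@@H]2O[C@H](CO)[C@@H](O)[C@H]2O)cc1I`: > 300000 nM (a limit)
- compound 2 `COC(=O)c1nn([C@@H]2O[C@H](CO)[C@@H](O)[C@H]2O)cc1I`: 900 nM
- compound 3 `O=C(O)c1nn([C@@H]2O[C@H](CO)[C@@H](O)[C@H]2O)cc1I`: > 300000 nM (a limit)

Compound 3 stands at the limit of > 300000 nM in this assay, at which 2 of the 3 values shown sit; this is a limit and not a number, and compound 1 shares it. Only compound 2 gives a measured number in this assay.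

The next compound is compound 4 `CCCCOC(=O)c1nn([C@@H]2O[C@H](CO)[C@@H](O)[C@H]2O)cc1I`, not yet measured. The change is butyl in place of hydrogen on an oxygen next to a carbonyl group.

The closest measured change sits at the same oxygen, with methyl in the place of the butyl: an at least 330-fold higher number from compound 2 to compound 3 (2.52 log units; beyond the scatter). Read backwards, this large step points to a much lower number once the hydrogen is replaced. The amide comparison agrees: an at least 330-fold lower number from compound 1 to compound 2 (2.52 log units; beyond the scatter), also large. The step that the two limits leave unreadable from compound 1 to compound 3 adds nothing. The series holds no measured ester with a chain longer than methyl, so the range stays wide and a somewhat higher number than that of compound 2 remains possible.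

A large fall in the number is therefore expected, estimated as an at least 100-fold lower number from compound 3 to compound 4 (2.00 log units; beyond the scatter). The estimated value for compound 4 is 3000 nM, with an expected range of 400 nM to 40000 nM.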

Compound 4, half-maximal inhibitory concentration: 21000 nM
Beside the measured number, compound 4's estimate is 7.0-fold (0.85 log units) below it, within the range that was stated.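

Compound 1 and compound 3 each remain a limit and not a number: the limit of > 300000 nM in this assay, at which 2 of the 4 values shown sit.

Against those limits, the butoxycarbonyl group still gives a readable number in this assay, so the fall in the number is not confined to the methyl ester: an at least 14-fold lower number from compound 3 to compound 4 (1.15 log units; beyond the scatter), and in the comparison with the amide, an at least 14-fold lower number from compound 1 to compound 4 (1.15 log units; beyond the scatter). The series also now has its first measured comparison of chain length at this oxygen, and the longer chain costs a large part of what the methyl ester gained: a 23-fold higher number from compound 2 to compound 4 (1.37 log units; beyond the scatter). Among the four compounds, both esters give measured numbers, neither the amide nor the acid does, and no compound goes against this, while compound 2 keeps the lowest number, with its steps to all the others beyond the scatter.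

Going by these compounds, with only methyl and butyl to compare, the shape of the chain-length trend stays open, and an ethyl, a propyl or a branched isopropyl ester could show whether the number rises steadily or changes abruptly. On these data alone, it also stays open whether a butyl group on the amide nitrogen would recover any readable number from the amide.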